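The source may hold more compounds than are shown below. What is called first, only, known or untested is meant among the compounds shown, and "the series" means these compounds.

Four thiourea-linked compounds share one core. Compound 1 `COc1ccc(C(=O)NC(=S)Nc2cccc(-c3nc4ccccc4[nH]3)c2)cc1OC` carries two methoxy groups on the benzoyl ring; compound 2 `Cc1ccc(-c2nc3ccccc3[nH]2)cc1NC(=S)NC(=O)c1ccc2c(c1)OCCO2` carries a methyl on the aniline ring and a fused dioxane ring on the benzoyl side; compound 3 `CCOc1ccc(C(=O)NC(=S)Nc2cc(-c3nc4ccccc4[nH]3)ccc2C)cc1OCC` combines that methyl with two ethoxy groups; compound 4 `CCOc1ccc(C(=O)NC(=S)Nc2cccc(-c3nc4ccccc4[nH]3)c2)cc1OCC` keeps the two ethoxy groups but lacks the methyl.

In a functional assay on HUVEC cells (Homo sapiens) for cytotoxicity, read by WST assay, with a stated time of 48 h (on this read-out lower numbers stand for stronger inhibition and higher numbers for weaker inhibition), compound 1 gives 6000 nM, and compound 2 gives 240 nM. For compound 3 the result in this assay is "not determined" (no result reported), so its standing cannot be placed against these two values.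

The move from compound 3 to compound 4 is small: hydrogen in place of methyl on an aromatic carbon. Among the compounds with values here, with no measured pair showing what this change does, the expected step in this assay is none beyond the usual scatter, in either direction. The estimate for compound 4 therefore leans on compound 1, which shares the unsubstituted aniline ring and gives 6000 nM. Compound 4 is expected to give about 4000 nM, within a range from 1000 nM to 15000 nM.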

Compound 4, half-maximal inhibitory concentration: 8000 nM
Compound 4: the middle estimate sits 2.0-fold (0.30 log units) below what was measured, and the stated range covers the measured number.
By their numbers in this assay, from the lowest: compound 2; then compounds 1 and 4 (each within the scatter of the next).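

Within the data shown here, with no number for compound 3 in this assay, compound 4 at 8000 nM gives no step to read. What hydrogen in place of methyl does to this read-out therefore stays open, and no evidence at hand explains the value of compound 4.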